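Amide series: methoxy added to the aryl of compound 2

This account rests on a few compounds, and the source may have more. Where it says the series, first, only, none or still open, it means among the compounds named here.

Measured so far:
compound 1, `Cn1c(-c2ccccc2)cnc1NC(=O)c1ccc(F)cc1`
compound 2, `Cc1ccccc1C(=O)Nc1ncc(-c2ccccc2)n1C`
compound 3, `Cn1c(-c2ccccc2)cnc1NC(=O)c1ccc(Cl)cc1`

In a toxicity assay on THP-1 cells (Homo sapiens) for inhibition (on this read-out lower numbers stand for higher toxicity in this test and higher numbers for lower toxicity in this test), compound 1 gives > 100000 nM, a limit of the assay rather than a number. Compound 2 likewise gives > 100000 nM, again only a limit. Compound 3 gives > 100000 nM, also a limit. Compound 2 therefore stands at the limit, as do the other two values shown: the limit of > 100000 nM in this assay, at which 3 of the 3 values shown sit. The steps among the measured compounds are accordingly unreadable: a step that the two limits leave unreadable from compound 1 to compound 2, a step that the two limits leave unreadable from compound 1 to compound 3 and a step that the two limits leave unreadable from compound 2 to compound 3.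

Compound 4, `COc1ccc(-c2cnc(NC(=O)c3ccccc3C)n2C)cc1`, has not yet been measured. It differs from compound 2 by methoxy in place of hydrogen on an aromatic carbon. Among the measured compounds shown here, none of the measured steps can be read in size, so none gives a direction or a size to expect; the only guidance is that every value so far sits at the limit. The step from compound 2 is expected to be a step that the limit leaves unreadable from compound 2 to compound 4. For compound 4 the expected value in this assay is 150000 nM, with a range from 40000 nM to 500000 nM, and most likely the assay again reports only a limit.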

Compound 4, half-maximal cytotoxic concentration: > 100000 nM
Compound 4 was reported as a limit (the forecaster's own chance of this, stated with the estimate: 80%); the middle value does not contradict the limit.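

In this assay compound 4 gives > 100000 nM, a limit and not a number. The step between compound 2 and compound 4 cannot be read, and the series remains at one value: the limit of > 100000 nM in this assay, at which 4 of the 4 values shown sit.

The compounds shown leave open whether any change in this series gives a measurable value on this read-out.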